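Azetidine amides on the oxadiazole core: urea to benzamide

A few compounds are considered here, and "the series" means these few. Any claim that something is new, unique, unknown or untested is made for them only; others in the source may bear on it.

The series shares an azetidine bearing a chlorophenyl- or fluorophenyl-substituted oxadiazole, with the azetidine nitrogen carrying either a urea or an aryl amide. Compound 1 `O=C(N1CCC(F)CC1)N1CC(c2nc(-c3cccc(Cl)c3)no2)C1` is the urea. In an assay on HEK293 cells for negative allosteric modulation of metabotropic glutamate receptor 5 (Homo sapiens), read by FLIPR (on this read-out higher numbers stand for weaker inhibition and lower numbers for stronger inhibition), compound 1 gives > 10000 nM, which is a limit of the assay and not a number. Compound 2 `O=C(c1ccc(F)c(F)c1)N1CC(c2nc(-c3cccc(F)c3)no2)C1`, a difluorobenzoyl amide with a fluorophenyl on the oxadiazole, stands in this assay at > 10000 nM, again a limit rather than a number. Going by the values given here, both values shown therefore sit at the limit of > 10000 nM in this assay, at which 2 of the 2 values shown sit, so no measured step within the set is available and compound 1 cannot be placed relative to compound 2.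

Compound 3 `O=C(c1cccc(F)c1)N1CC(c2nc(-c3cccc(Cl)c3)no2)C1` carries 3-fluorophenyl in place of 4-fluoropiperidin-1-yl on a carbonyl carbon. Compound 2 shows that a benzoyl amide on this core with a fluorophenyl oxadiazole gives no numerical value in this assay, so a step from compound 1 to compound 3 beyond the scatter is not expected in either direction; the expected step is an at least 1.1-fold lower number from compound 1 to compound 3 (0.04 log units; that floor lies within the scatter). Compound 3 is thus estimated in this assay at 9000 nM, within 1500 nM to 40000 nM, most likely reported only as a limit.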

Compound 3, half-maximal inhibitory concentration: 780 nM
Compound 3: middle estimate off by 12-fold (1.06 log units), on the high side, and the stated range ends above it.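

In this assay the change on the carbonyl carbon, 3-fluorophenyl in place of 4-fluoropiperidin-1-yl, gives an at least 12-fold lower number from compound 1 to compound 3 (1.10 log units; beyond the scatter). Going by these compounds alone, this is the first sign that the group on this carbonyl carbon can move the read-out from the limit of the assay to a numerical value, at least with the rest of compound 3 held as it is. The size of the step is only a floor, as compound 1 stands at a limit and not at a number: the limit of > 10000 nM in this assay, at which 2 of the 3 values shown sit.

Within the data shown here, compound 2 differs from compound 3 in more than one place, so no step between them can be read, and it stays open which of those differences separates a limit from a number. Also open, from the compounds shown here alone, is how far the gain belongs to the aromatic ring and how far to its fluorine, which a plain phenyl, a pyridine ring or a piperidine without fluorine on the same carbonyl carbon would address, along with whether the step holds when the chlorophenyl on the shared core is replaced by a fluorophenyl.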